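From cyclopropyl to cyclopentyl on a sulfonamide nitrogen

A few compounds are considered here, and "the series" means these few. Any claim that something is new, unique, unknown or untested is made for them only; others in the source may bear on it.

Measured in a functional assay on MM1.S cells (Homo sapiens) for inhibition, with a stated time of 72 h; a lower number here means a stronger inhibitor, a higher number a weaker inhibitor:
compound 1 `O=C(NO)c1ccc(CN(C2CC2)S(=O)(=O)c2cc(F)c(F)c(F)c2F)cc1` gives 480 nM
compound 2 `CC(C)N(Cc1ccc(C(=O)NO)cc1)Cc1cc(F)c(F)c(F)c1F` gives 11400 nM

Of these two, compound 1 has the lower number and is the stronger inhibitor, with a gap to compound 2 that lies beyond the scatter. Compound 3 `O=C(NO)c1ccc(CN(C2CCCC2)S(=O)(=O)c2cc(F)c(F)c(F)c2F)cc1` keeps the core of compound 1 but carries cyclopentyl in place of cyclopropyl on a sulfonamide nitrogen. For the measured compounds named here, no measured pair shows this kind of change on its own, so the expectation is tentative. In this assay a small move toward weaker inhibition, within the scatter, is expected, estimated as a 1.3-fold higher number from compound 1 to compound 3 (0.10 log units; within the scatter) here. Compound 3 is estimated at 600 nM (expected range 200 nM to 1800 nM).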

Compound 3, half-maximal inhibitory concentration: 3300 nM
Compound 3: the middle estimate sits 5.5-fold (0.74 log units) below what was measured, and the stated range ends below it.
By their numbers in this assay, from the lowest: compound 1; then compound 3; then compound 2.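

In this assay, the sulfonamide nitrogen proves sensitive to its ring substituent: cyclopentyl in place of cyclopropyl gives a 6.9-fold higher number from compound 1 to compound 3 (0.84 log units; beyond the scatter), a loss of inhibition beyond the scatter. For the compounds shown here, this is the first single-place change, and it shows that this position does not tolerate the swap freely. Nothing available accounts for this step. The compounds shown leave open how cyclobutyl or an open chain such as ethyl would behave on this nitrogen, and whether the loss grows steadily with ring size.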